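The source may hold more compounds than are shown below. What is called first, only, known or untested is meant among the compounds shown, and "the series" means these compounds.

Compound 1 `O=C1[C@@H](NS(=O)(=O)c2ccc3cc(Cl)ccc3c2)CCN1c1ccc2c(c1)CCNC2`: 24%
Compound 2 `O=C1[C@@H](NS(=O)(=O)c2ccc3c(Cl)c[nH]c3c2)CCN1c1ccc2c(c1)CCNC2`: < 1%
Compound 3 `O=C1[C@@H](NS(=O)(=O)c2ccc3cc(Cl)ccc3c2)CCN1c1cc2c(cc1F)CNCC2`: 28%

In an in vivo ADME assay on the whole organism (strain Sprague-Dawley) for pharmacokinetics, with Rattus norvegicus as the target (a lower number here means that a smaller share of the oral dose reaches the circulation, a higher number that a larger share of the oral dose reaches the circulation), compound 1 gives 24% and compound 3 gives 28%. Compound 3 differs from compound 1 by fluoro in place of hydrogen on an aromatic carbon, and the resulting step is a number 4 percentage points higher from compound 1 to compound 3 (within the scatter). In this assay compound 2 gives < 1%, which is a limit of the assay and not a number. This is the limit of < 1% in this assay, at which 1 of the 3 values shown sits. The difference between the cores of compound 1 and compound 2 is not broken down here.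

Compound 4 `O=C1[C@@H](NS(=O)(=O)c2ccc3c(Cl)c[nH]c3c2)CCN1c1cc2c(cc1F)CNCC2` has not yet been measured in this assay. It differs from compound 2 by fluoro in place of hydrogen on an aromatic carbon, the same change as from compound 1 to compound 3. Because the earlier step was a number 4 percentage points higher from compound 1 to compound 3 (within the scatter), the step from compound 2 to compound 4 is expected to be a number no lower from compound 2 to compound 4 (the limit leaves the size open). Compound 4 is therefore estimated at 1%, expected to lie between 0% and 6%.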

Compound 4, oral bioavailability: 6%
Compound 4: middle estimate off by 5 percentage points, on the low side; the range from low to high includes it.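

In this assay, fluoro in place of hydrogen on an aromatic carbon on the core of compound 2 gives this step: a number at least 5 percentage points higher from compound 2 to compound 4 (that floor lies within the scatter). Set beside the step on the core of compound 1, the result reads: the same change on two cores in this assay, a number 4 percentage points higher (within the scatter) from compound 1 to compound 3 and a number at least 5 percentage points higher (that floor lies within the scatter) from compound 2 to compound 4; the limit leaves it open whether they differ This does not show that the change carries over at the same size, as the value for compound 2 is a limit of the assay and the true size of the step stays open, and two cores do not make a rule for the series.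

The compounds shown leave open how a methyl, a methoxy or a nitrile at the same place would compare with fluoro. They also leave open whether fluoro would give a similar result on other cores.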